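The compounds below may be only part of what the source reports. "The series", "measured", "known", "first", "only" and "open" are said of these compounds alone.

Measured so far:
compound 1 `Cc1nc(N2CCN(C)CC2)c2nc(-c3ccccc3F)n(C3CCOCC3)c2n1` with 10%
compound 2 `Cc1nc(N2CCN(C)CC2)c2nc(-c3ccccc3C3CC3)n(C3CCOCC3)c2n1` with 33%

These numbers come from an ADME assay (liver) for metabolic stability, with Liver microsome (Homo sapiens) as the target, read by LC-MS, using microsomes, with a stated time of 30 min, tested at 4 uM; on this read-out higher numbers stand for a more stable compound and lower numbers for a less stable compound. Compound 2 holds the higher of the two numbers, at 33%. Compound 3 `COc1ccc(-c2nc3c(N4CCN(C)CC4)nc(C)nc3n2C2CCOCC2)c(C)c1` has not yet been measured. It keeps the shared core and carries 4-methoxy-2-methylphenyl in place of 2-cyclopropylphenyl on an aromatic carbon.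

Among the compounds with values here, only one measured step bears on this swap, as it also alters the group at this place: a number 23 percentage points higher from compound 1 to compound 2 (beyond the scatter). It is modest but beyond the scatter, so the group at this place can shift the read-out. Within the data shown here, no measured compound carries a methoxy group, however, so the step gives only a rough guide to size and none to direction. Since compound 2 at 33% is the higher of just two numbers, a modest drop seems the likelier outcome. The expected change is a number 13 percentage points lower from compound 2 to compound 3 (beyond the scatter). For compound 3 the estimated value is 20%, with an expected range from 7% to 40%.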

Compound 3, percent of the compound remaining: 21%
Estimate against measurement, compound 3: 1 percentage points below, within the range that was stated.
By their numbers in this assay, from the lowest: compound 1; then compound 3; then compound 2.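

In this assay, this place on the shared core has now held three different substituted phenyl groups, and the newest reads between the other two: 4-methoxy-2-methylphenyl in place of 2-cyclopropylphenyl gives a number 12 percentage points lower from compound 2 to compound 3 (beyond the scatter), while the same group in place of 2-fluorophenyl gives a number 11 percentage points higher from compound 1 to compound 3 (beyond the scatter). The read-out at this position therefore takes at least three distinct levels, rather than just the two seen earlier. The 2-cyclopropylphenyl and 4-methoxy-2-methylphenyl groups also have the same count of heavy atoms, so that count alone does not set the number here, and nothing available explains why the three groups fall in this order.

The 4-methoxy-2-methylphenyl group differs from the other two groups in more than one way, so the compounds shown cannot separate what the methoxy group and the methyl group each contribute. They also leave open how a phenyl ring carrying an amine or a carboxylic acid would read at this place, and whether the same swaps would have similar effects with a different group elsewhere on the core.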